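A Methyl for a Fluoro on the Aryl Triazole

The source may report more compounds than this note shows. Statements on the series, on what has been measured and on what is new or still open speak of the compounds shown alone.

Compound 2 `C=C1C(=O)[C@]23C[C@@]1(O)CC[C@H]2c1ccc(O)c(C)c1[C@@H]3Cn1cc(-c2ccc(F)cc2)nn1` is measured in a functional assay on SW480 cells (Homo sapiens) for cytotoxicity, read by MTT assay, with a stated time of 4 days (a lower number here means a stronger inhibitor, a higher number a weaker inhibitor), and gives 250 nM. Compound 1 `C=C1C(=O)[C@]23C[C@@]1(O)CC[C@H]2c1ccc(O)c(C)c1[C@@H]3Cn1cc(-c2ccccc2)nn1` gives 260 nM in the same this assay, and the two numbers stand side by side within the usual scatter, so neither can be placed above the other. Compound 3 `C=C1C[C@]23C[C@@]1(O)CC[C@H]2c1ccc(OS(=O)(=O)c2ccc(C)cc2)c(C)c1[C@@H]3Cn1cc(-c2ccc(F)cc2)nn1` returns only a limit in this assay, > 20000 nM, which is not a number; it carries a tosylate and lacks the carbonyl, so it does not speak to the change considered here (the limit of > 20000 nM in this assay, at which 1 of the 3 values shown sits).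

The step to compound 4 `C=C1C(=O)[C@]23C[C@@]1(O)CC[C@H]2c1ccc(O)c(C)c1[C@@H]3Cn1cc(-c2ccc(C)cc2)nn1` is methyl in place of fluoro on an aromatic carbon. For the measured compounds named here, the one measured step on this part of the molecule, a 1.0-fold lower number from compound 1 to compound 2 (0.02 log units; within the scatter), showed that swapping hydrogen for fluoro at this position left the read-out where it was. Replacing that fluoro with methyl is therefore expected to give no movement beyond the scatter, no change at the digits printed from compound 2 to compound 4 (within the scatter). Compound 4 is estimated to give 250 nM in this assay, with a likely range from 120 nM to 550 nM.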

Compound 4, half-maximal inhibitory concentration: 330 nM
Estimate against measurement, compound 4: 1.3-fold (0.12 log units) below; the range from low to high includes it.
By their numbers in this assay, from the lowest: compounds 2, 1 and 4 (each within the scatter of the next). At a limit, above all of these: compound 3.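

At the 4-position of the phenyl on the triazole, a carbon-bearing group has now been tested as well: in this assay, methyl in place of fluoro (a 1.3-fold higher number from compound 2 to compound 4 (0.12 log units; within the scatter)) and methyl in place of hydrogen (a 1.3-fold higher number from compound 1 to compound 4 (0.10 log units; within the scatter)) both stay within the scatter. Together with the earlier step, this means hydrogen, fluoro and methyl at this place, para to a large group, all read alike, so the read-out does not separate compound 1, compound 2 and compound 4. Nothing measured here gives a reason for this.

As far as these compounds go, whether this tolerance extends to an amine, a carboxylic acid or a longer chain at the same place remains open. So does whether any group here can move the read-out beyond the scatter in either direction.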